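Cyclopropyl for 4-bromophenyl: working notes on compound 4

The compounds below may be only part of what the source reports. "The series", "measured", "known", "first", "only" and "open" are said of these compounds alone.

Measured so far in a functional assay on HeLa cells (Homo sapiens) for antiproliferative activity, read by MTT assay, with a stated time of 72 h (a lower number here means a stronger inhibitor, a higher number a weaker inhibitor), for this series:
- compound 1 `O=C1O[C@H]([C@@H](O)Cn2cc(-c3ccc(Br)cc3)nn2)C(OCc2ccccc2)=C1OCc1ccccc1` at 3910 nM
- compound 2 `Cc1ccc(-c2cn(C/C=C3\OC(=O)C(OCc4ccccc4)=C3OCc3ccccc3)nn2)cc1` at 7480 nM
- compound 3 `O=C1O/C(=C\Cn2cc(-c3cc(F)cc(F)c3)nn2)C(OCc2ccccc2)=C1OCc1ccccc1` at 17700 nM

Compound 1 and compound 2 lie within the scatter of each other, while compound 3 stands higher than compound 1 by more than the scatter. Compound 4 `O=C1O[C@H]([C@@H](O)Cn2cc(C3CC3)nn2)C(OCc2ccccc2)=C1OCc1ccccc1` keeps the core of compound 1 and has cyclopropyl in place of 4-bromophenyl on an aromatic carbon. Counted out, the change reads cyclopropyl in place of 4-bromophenyl on an aromatic carbon and leaves no aromatic group at that place.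

Among the compounds with values here, only one measured step bears on this place: a 2.4-fold higher number from compound 2 to compound 3 (0.37 log units; beyond the scatter) on a core that differs from that of compound 1. That step exchanges one substituted phenyl for another. Within the data shown here, no measured compound carries a non-aromatic group there, so the data bound the size of the new step only loosely. Among the measured compounds shown here, a rise somewhat larger than the one seen for compound 3 is expected, with a wide margin. The expected step is a 2.3-fold higher number from compound 1 to compound 4 (0.36 log units; beyond the scatter) on this estimate. Compound 4 is expected at 9000 nM in this assay with an estimated range from 3000 nM to 30000 nM as its bounds.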

Compound 4, half-maximal inhibitory concentration: 26500 nM
Compound 4: middle estimate off by 2.9-fold (0.47 log units), on the low side, within the range that was stated.
By their numbers in this assay, from the lowest: compounds 1 and 2 (each within the scatter of the next); then compounds 3 and 4 (each within the scatter of the next).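

In this assay the exchange of 4-bromophenyl for cyclopropyl gives a 6.8-fold higher number from compound 1 to compound 4 (0.83 log units; beyond the scatter) and is the first step shown at this place that leaves the aromatic groups, since the earlier step only exchanged one substituted phenyl for another. On the core of compound 1, cyclopropyl therefore does not hold the number reached with 4-bromophenyl, but the change removes the bromine and the aromatic ring and also shortens the group, so this single step cannot separate these differences. No measurement shown here accounts for the rise.

Still open, going by these compounds, is whether the aromatic ring, the bromine or the size of the group governs the number at this place. An unsubstituted phenyl and a cyclohexyl group on the same core would help to separate these three.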